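Trifluoromethyl gives way to nitro in compound 4

The source may hold more compounds than are shown below. What is called first, only, known or untested is meant among the compounds shown, and "the series" means these compounds.

In an ADME assay on Vero cells (Chlorocebus sabaeus) for cytotoxicity, read by resazurin assay, with a stated time of 72 h (a higher number here means a weaker inhibitor, a lower number a stronger inhibitor), compound 1 (`O=C(CCN1CCN(c2ccc([N+](=O)[O-])cc2)CC1)c1ccc(F)cc1`) gives 111000 nM and compound 2 (`O=C(CCN1CCN(c2ccc(F)cc2)CC1)c1ccc(C(F)(F)F)cc1`) gives 28500 nM while compound 3 (`O=C(CCN1CCN(c2ccc(C(F)(F)F)cc2)CC1)c1ccc(C(F)(F)F)cc1`) gives 49200 nM as its number. Compound 3 thus stands within the usual scatter of compound 2, and compound 1 lies clearly higher than compound 3.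

Compound 4 (`O=C(CCN1CCN(c2ccc([N+](=O)[O-])cc2)CC1)c1ccc(C(F)(F)F)cc1`) has nitro in place of trifluoromethyl on an aromatic carbon of compound 3 (nitro in place of trifluoromethyl on an aromatic carbon). Among the compounds with values here, the one measured step at this spot is a 1.7-fold higher number from compound 2 to compound 3 (0.24 log units; within the scatter) for trifluoromethyl in place of fluoro, so that step alone points to no large move. Compound 1 also carries nitro, and its 111000 nM reading leans upward, but it differs elsewhere in the structure as well. In this assay the step expected is therefore small and upward (a 1.3-fold higher number from compound 3 to compound 4 (0.12 log units; within the scatter)). Compound 4 is estimated at 65000 nM with 30000 nM to 130000 nM as its expected range.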

Compound 4, half-maximal inhibitory concentration: 75700 nM
Compound 4: the middle estimate sits 1.2-fold (0.07 log units) below what was measured; the measured number falls inside the stated range.
By their numbers in this assay, from the lowest: compounds 2, 3, 4 and 1 (each within the scatter of the next, the first and the last beyond it).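

In this assay, the step of a 1.5-fold higher number from compound 3 to compound 4 (0.19 log units; within the scatter) means that nitro and trifluoromethyl cannot be told apart at this aromatic carbon when the rest of the structure stays fixed. Fluoro at the same carbon does separate from nitro, with a 2.7-fold higher number from compound 2 to compound 4 (0.42 log units; beyond the scatter), the first step at this spot to go beyond the scatter. Trifluoromethyl in place of fluoro at the other aromatic carbon gives a 1.5-fold lower number from compound 1 to compound 4 (0.17 log units; within the scatter), and the two readings of this change do not differ by more than two such steps can scatter: the same change on two cores in this assay, a 1.7-fold higher number (0.24 log units; within the scatter) from compound 2 to compound 3 and a 1.5-fold lower number (0.17 log units; within the scatter) from compound 1 to compound 4, 2.5-fold (0.40 log units) apart, within the scatter of two such steps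

The compounds shown leave open whether an amine, a carboxylic acid or a nitrile at this aromatic carbon would move the number further. They also leave open what a longer chain between the carbonyl and the shared core's nitrogen-bearing ring would do.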